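Adding a second methoxy to compound 2

This account rests on a few compounds, and the source may have more. Where it says the series, first, only, none or still open, it means among the compounds named here.

In a functional assay on HeLa cells (Homo sapiens) for inhibition, read by MTT assay, with a stated time of 72 h (a higher number here means a weaker inhibitor, a lower number a stronger inhibitor), compound 1 `C=C(Br)C(=O)Nc1cccc(/C=C/C(=O)Nc2cccc(F)c2)c1` gives 1200 nM and compound 2 `C=C(Br)C(=O)Nc1cccc(/C=C/C(=O)Nc2ccc(OC)cc2)c1` gives 790 nM. Among the compounds with values here, the two values lie within the scatter of each other, so compound 2 cannot be separated from its only measured neighbour. Compound 3 `C=C(Br)C(=O)Nc1cccc(/C=C/C(=O)Nc2ccc(OC)c(OC)c2)c1` carries one further change on the same aryl group of the amide-type nitrogen: methoxy in place of hydrogen on an aromatic carbon. The added methoxy sits ortho to a methoxy group already present. Within the data shown here, only one measured step bears on this change, a 1.5-fold lower number from compound 1 to compound 2 (0.18 log units; within the scatter), and it altered the group on that same nitrogen. Among the measured compounds shown here, no measured step shows what a second methoxy does on its own, so no shift beyond the scatter is expected in this assay. The expected change is a 1.1-fold lower number from compound 2 to compound 3 (0.05 log units; within the scatter). For compound 3 the estimated value is 700 nM, with an expected range of 300 nM to 1600 nM.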

Compound 3, half-maximal inhibitory concentration: 560 nM
Beside the measured number, compound 3's estimate is 1.3-fold (0.10 log units) above it; measured number inside the range.
By their numbers in this assay, from the lowest: compounds 3, 2 and 1 (each within the scatter of the next, the first and the last beyond it).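

In this assay, within the data shown here, methoxy in place of hydrogen on an aromatic carbon, ortho to a methoxy group and meta to a large group, gives a 1.4-fold lower number from compound 2 to compound 3 (0.15 log units; within the scatter) and so isolates this one change for the first time. The earlier step replaced one whole aryl group with another, whereas this one shows that this position takes a second methoxy with no shift that can be told from the scatter. No measurement shown here accounts for this result.

From the compounds shown here alone, whether a longer chain such as ethoxy, or a group of another kind such as an amine or a carboxylic acid, would move the number beyond the scatter at this position remains open. Also open, going by these compounds, is whether methoxy here would give the same result without the first methoxy in place.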